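A few compounds are considered here, and "the series" means these few. Any claim that something is new, unique, unknown or untested is made for them only; others in the source may bear on it.

Measured compounds:

Compound 1, `COc1ccc2c(c1)NC(=O)CN2c1nc(NCCCO)nc2ccccc12`: 5.18 nM in a functional assay on A549 cells (Homo sapiens) for inhibition, read by sulforhodamine B assay, with a stated time of 48 h; on this read-out lower numbers stand for stronger inhibition of growth and higher numbers for weaker inhibition of growth
Compound 2, `COc1ccc2c(c1)NC(=O)CN2c1nc(Nc2cccc(C#N)c2)nc2ccccc12`: 75.4 nM in this assay
Compound 3, `COc1ccc2c(c1)NC(=O)CN2c1nc(COC(C)=O)nc2ccccc12`: 5.52 nM in this assay

Compound 2 gives the highest number of the three. Going from compound 2 to compound 3 brings a 14-fold lower number from compound 2 to compound 3 (1.14 log units; beyond the scatter), and going from compound 1 to compound 2 brings a 15-fold higher number from compound 1 to compound 2 (1.16 log units; beyond the scatter), both beyond the scatter. Compound 1 and compound 3 sit close together, with a 1.1-fold higher number from compound 1 to compound 3 (0.03 log units; within the scatter).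

Compound 4, `COc1ccc2c(c1)NC(=O)CN2c1nc(N2CC(OC)C2)nc2ccccc12`, is not yet measured. It differs from compound 2 in one place: 3-methoxyazetidin-1-yl in place of (3-cyanophenyl)amino on an aromatic carbon. The two measured steps bear on this directly, since each swaps the group at this same position and each is large. Both point the same way: the (3-cyanophenyl)amino group goes with the highest number, and the two other groups tried there give numbers close to each other. No measurement tests 3-methoxyazetidin-1-yl itself, so the range is kept wide. Compound 4 is therefore expected to give 8 nM, with a range from 3 nM to 30 nM. The expected step is a 9.4-fold lower number from compound 2 to compound 4 (0.97 log units; beyond the scatter), downward and beyond the scatter.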

Compound 4, concentration for 50% growth inhibition: 17.5 nM
Compound 4: middle estimate off by 2.2-fold (0.34 log units), on the low side; the range from low to high includes it.
By their numbers in this assay, from the lowest: compounds 1 and 3 (each within the scatter of the next); then compound 4; then compound 2.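

In this assay, the aromatic carbon between two ring nitrogen atoms turns out not to be a simple two-level switch, with (3-cyanophenyl)amino on one side and everything else on the other. Replacing (3-cyanophenyl)amino with 3-methoxyazetidin-1-yl closes only part of the gap, giving a 4.3-fold lower number from compound 2 to compound 4 (0.63 log units; beyond the scatter), yet the new group still falls short of the other two groups, with a 3.2-fold higher number from compound 3 to compound 4 (0.50 log units; beyond the scatter) and a 3.4-fold higher number from compound 1 to compound 4 (0.53 log units; beyond the scatter), so compound 4 occupies a middle level, and the choice among non-aryl groups at this carbon also matters. Nothing available explains why the groups rank in this order.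

Going by these compounds, whether the methoxy group or the four-membered ring sets the value of compound 4 remains open. A plain azetidin-1-yl group or a morpholin-4-yl group at this carbon would help separate the two.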